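The source may hold more compounds than are shown below. What is called first, only, known or untested is meant among the compounds shown, and "the series" means these compounds.

Compound 1 `Cn1c(/C=C2\SC(=O)N(CC(=O)N3CCOCC3)C2=O)nc2ccccc21` and compound 2 `CC(C)n1c(/C=C2\SC(=O)N(CC(=O)N3CCOCC3)C2=O)nc2ccccc21` share one core; compound 3 `COc1cc2c(cc1OC)CN(C(=O)CN1C(=O)S/C(=C\c3nc4ccccc4n3C(C)C)C1=O)CC2` has another, and how its core differs from that of compound 2 is not broken down here. In a functional assay on PC-3 cells (Homo sapiens) for inhibition, read by MTT assay, with a stated time of 48 h (a lower number here means a stronger inhibitor, a higher number a weaker inhibitor), compound 1 gives > 50000 nM, which is a limit of the assay and not a number. In this assay compound 2 gives > 50000 nM, also a limit. In this assay compound 3 gives > 50000 nM, again a limit. The change from compound 2 to compound 1 is methyl in place of isopropyl on an aromatic nitrogen, and its step is a step that the two limits leave unreadable from compound 2 to compound 1. Compound 4 `COc1cc2c(cc1OC)CN(C(=O)CN1C(=O)S/C(=C\c3nc4ccccc4n3C)C1=O)CC2` carries the same change on the core of compound 3: methyl in place of isopropyl on an aromatic nitrogen. Because every measured value sits at the limit of > 50000 nM in this assay, at which 3 of the 3 values shown sit, the step that the limit leaves unreadable from compound 3 to compound 4 is expected to stay unreadable. Compound 4 is therefore estimated at 60000 nM, between 20000 nM and 200000 nM, most likely reported only as a limit.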

Compound 4, half-maximal inhibitory concentration: 41100 nM
For compound 4 the middle estimate is 1.5-fold (0.16 log units) above the measured one; the measured number falls inside the stated range.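

In this assay, methyl in place of isopropyl on an aromatic nitrogen gives an at least 1.2-fold lower number from compound 3 to compound 4 (0.08 log units; that floor lies within the scatter), so on this core the change has only a floor, and that floor does not go beyond the usual scatter. The same change on the core of compound 2 cannot be read, because the values there are limits of the assay and not numbers: the limit of > 50000 nM in this assay, at which 3 of the 4 values shown sit. The result therefore gives compound 4 a measured number, but it does not show how large the step really is or that the change acts alike on both cores.

The compounds shown leave open what an ethyl group, or a longer chain ending in an amine, would do on that aromatic nitrogen. They also leave open whether the same change could be read on a third core.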